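Stability in buffer after swapping an acetyl for a valine ester

This account rests on a few compounds, and the source may have more. Where it says the series, first, only, none or still open, it means among the compounds named here.

Of the compounds shown here, two from this study have been tested in a physicochemical assay for metabolic stability, read by LC-MS, in phosphate buffer, with a stated time of 3 h, at pH 7.4, tested at 50 uM; a lower number here means that less of the compound is left, a higher number that more of the compound is left. The first, compound 1, has the structure `Cc1oc(=O)oc1COC(=O)c1cccc(NC(=O)[C@@H]2C[C@H](SC3=C(C(=O)O)N4C(=O)[C@H]([C@@H](C)O)[C@H]4[C@H]3C)CN2)c1`. In this assay compound 1 gives > 95%, which is a limit of the method rather than a number. The second, compound 2, has the structure `CCOC(=O)C1=C(S[C@@H]2CN[C@H](C(=O)Nc3cccc(C(=O)OCC)c3)C2)[C@H](C)[C@@H]2[C@@H]([C@@H](C)OC(C)=O)C(=O)N12`. In this assay compound 2 likewise gives > 95%, again a limit and not a number. Compound 2 therefore stands where both measured values sit, at the top edge of what the assay can report, as shown by the limit of > 95% in this assay, at which 2 of the 2 values shown sit.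

The unmeasured compound 3 has the structure `CCOC(=O)C1=C(S[C@@H]2CN[C@H](C(=O)Nc3cccc(C(=O)OCC)c3)C2)[C@H](C)[C@@H]2[C@@H]([C@@H](C)OC(=O)[C@@H](N)C(C)C)C(=O)N12`. It differs from compound 2 in one place: 1-amino-2-methylpropyl in place of methyl on a carbonyl carbon, so that acetoxy becomes ((1-amino-2-methylpropyl)carbonyl)oxy. Among the compounds with values here, no measured pair shows the effect of this change in this assay, so the expectation rests only on the limit seen for compound 2. A modest fall, somewhat beyond the usual scatter, is expected, giving the step of a number at least 10 percentage points lower from compound 2 to compound 3 (that floor lies within the scatter). Compound 3 is accordingly estimated at 85%, with a likely range from 60% to 97%.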

Compound 3, percent of the compound remaining: > 95%
Compound 3 was reported as a limit (the forecaster's own chance of this, stated with the estimate: 40%); at least 10 percentage points between middle value and limit.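

In this assay compound 3 gives > 95%, which is a limit and not a number. Compound 2 sits at a limit too, so the step from it to compound 3 cannot be read. The compounds shown therefore leave open whether 1-amino-2-methylpropyl in place of methyl on a carbonyl carbon changes the amount remaining at all: the limit of > 95% in this assay, at which 3 of the 3 values shown sit.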